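The source may report more compounds than this note shows. Statements on the series, on what has been measured and on what is new or still open speak of the compounds shown alone.

For the measured compounds named here, compound 2, `NC(=O)c1ccc(N/N=C(/S)NC(c2ccccc2)c2ccccc2)c([N+](=O)[O-])c1`, gives 1.8 nM in an assay on cell membranes for inhibition of B2 bradykinin receptor (Rattus norvegicus) (a lower number here means a stronger inhibitor, a higher number a weaker inhibitor), the lowest of the two numbers known, while compound 1, `O=[N+]([O-])c1ccccc1N/N=C(/S)NC(c1ccccc1)c1ccccc1`, gives 38 nM. Going by the values given here, the one measured step, a 21-fold lower number from compound 1 to compound 2 (1.32 log units; beyond the scatter), shows that a substituent at this place of the shared core matters greatly. Compound 3, `NS(=O)(=O)c1ccc(N/N=C(/S)NC(c2ccccc2)c2ccccc2)c([N+](=O)[O-])c1`, carries sulfamoyl in place of carbamoyl on an aromatic carbon. Among the compounds with values here, no measured step compares these two groups, so compound 3 is expected to stay close to compound 2, with a 1.7-fold higher number from compound 2 to compound 3 (0.22 log units; within the scatter) not beyond the scatter. Compound 3 is therefore estimated at 3 nM, within 1 nM to 10 nM.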

Compound 3, inhibition constant: 4 nM
The estimate for compound 3 lay 1.3-fold (0.12 log units) below the measured number; measured number inside the range.
By their numbers in this assay, from the lowest: compound 2; then compound 3; then compound 1.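

In this assay the position tells the two groups apart, though only modestly, with a 2.2-fold higher number from compound 2 to compound 3 (0.35 log units; beyond the scatter) as the step between them. Sulfamoyl in place of hydrogen still gives a 9.5-fold lower number from compound 1 to compound 3 (0.98 log units; beyond the scatter), so the lower number is not confined to carbamoyl, although carbamoyl's step from compound 1 remains the larger. Nothing available explains the difference between these groups.

Going by these compounds, whether an amine or a carboxylic acid at this place would also give a lower number than hydrogen remains open. So does whether a methyl group on the amide or sulfonamide nitrogen would be tolerated.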